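Working notes on the series: compound 1 to compound 3

The source may hold more compounds than are shown below. What is called first, only, known or untested is meant among the compounds shown, and "the series" means these compounds.

Measured compounds:
compound 1, `O=C(Nc1ccccc1F)Nc1cc2ncncc2cc1OCc1cccc(F)c1`: 8100 nM
compound 2, `O=C(Nc1ccccc1F)Nc1cc2ncncc2cc1OCc1ccccc1F`: 3800 nM

Among the measured compounds shown here, in a functional assay on GBM3 cells (Homo sapiens) for antiproliferative activity, read by WST assay, with a stated time of 72 h (a lower number here means a stronger inhibitor, a higher number a weaker inhibitor), compound 1 gives 8100 nM, the higher of the two numbers measured so far; compound 2 gives 3800 nM. For the measured compounds named here, the single measured step, a 2.1-fold lower number from compound 1 to compound 2 (0.33 log units; beyond the scatter), concerns only the fluorophenyl attached through the saturated chain carbon to the oxygen on the aromatic ring, and that part of the molecule is kept unchanged in what follows.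

Compound 3, `O=C(Nc1ccc(C(F)(F)F)cc1)Nc1cc2ncncc2cc1OCc1cccc(F)c1`, differs from compound 1 at the other end: 4-(trifluoromethyl)phenyl in place of 2-fluorophenyl on an amide-type nitrogen. Going by the values given here, no measured pair touches the group on this amide-type nitrogen, so the step from compound 1 to compound 2 does not bear on the change and supplies no direction. With nothing else to go on, the expectation for compound 3 is a number close to that of compound 1, a 1.0-fold lower number from compound 1 to compound 3 (0.01 log units; within the scatter), with a wide allowance either way. The estimated value for compound 3 in this assay is 8000 nM, expected to fall between 2500 nM and 25000 nM.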

Compound 3, half-maximal inhibitory concentration: 6300 nM
Beside the measured number, compound 3's estimate is 1.3-fold (0.10 log units) above it; low and high end bracket the measured number.
By their numbers in this assay, from the lowest: compounds 2, 3 and 1 (each within the scatter of the next, the first and the last beyond it).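

In this assay the group on the amide-type nitrogen now has a measured step of its own, since 4-(trifluoromethyl)phenyl in place of 2-fluorophenyl gives a 1.3-fold lower number from compound 1 to compound 3 (0.11 log units; within the scatter) and so leaves the two numbers inseparable. This end of the molecule therefore takes an exchange to a group with more heavy atoms, with the fluorine count going from 1 to 3, without a change that stands out from repeated measurement, which the earlier step at the other end could not show. Nothing at hand bears on the reason for this result.

The single step alters the substitution on the phenyl ring in more than one way at once, so the compounds shown do not say whether 2-(trifluoromethyl)phenyl or 4-fluorophenyl on the same nitrogen would behave alike, nor how a phenyl carrying an amine or a carboxylic acid, or a saturated alkyl chain in place of the phenyl, would read. They also leave open whether the step from 3-fluorophenyl to 2-fluorophenyl at the other end would carry over with 4-(trifluoromethyl)phenyl on the amide-type nitrogen.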